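The source may report more compounds than this note shows. Statements on the series, on what has been measured and on what is new or still open speak of the compounds shown alone.

Measured compounds:
- compound 1 `O=C(Nc1cccc(-n2cc(-c3ccncc3)c(-c3cc(O)cc(Cl)c3)n2)c1)Nc1ccc(Cl)c(Cl)c1`: 82%
- compound 2 `COc1cc(Cl)cc(-c2nn(-c3cccc(NC(=O)Nc4cc(C(F)(F)F)cc(C(F)(F)F)c4)c3)cc2-c2ccncc2)c1`: 7%

In a functional assay on HCT-116 cells (Homo sapiens) for inhibition, read by sulforhodamine B assay, with a stated time of 48 h, tested at 1 uM (on this read-out lower numbers stand for a stronger effect and higher numbers for a weaker effect at the one concentration tested), compound 1 gives 82%, the highest of the two numbers, which on this read-out means the weaker effect. Compound 2 gives 7% in this assay, a number far lower than that of compound 1 and well beyond the usual scatter. Among the measured compounds shown here, compound 2 differs from compound 1 in more than one place, so no single step between the two can be described.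

Compound 3 `COc1cc(Cl)cc(-c2nn(-c3cccc(NC(=O)Nc4ccc(Cl)c(Cl)c4)c3)cc2-c2ccncc2)c1` has not yet been measured in this assay. It differs from compound 1 in one place: methyl in place of hydrogen on an oxygen on an aromatic ring.

Nothing measured here isolates this change, so the expectation is uncertain. Compound 3 is expected to give about 45% in this assay, within a range from 8% to 85%, the estimated step of a number 37 percentage points lower from compound 1 to compound 3 (beyond the scatter) pointing to a lower number.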

Compound 3, a percentage reported as activity, at one concentration (the size of the read-out at that concentration, not a potency): 71%
Estimate against measurement, compound 3: 26 percentage points below; the measured number falls inside the stated range.
By their numbers in this assay, from the lowest: compound 2; then compound 3; then compound 1.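

Placing a methyl on the oxygen, which turns hydroxy into methoxy on the aromatic ring, gives in this assay a number 11 percentage points lower from compound 1 to compound 3 (beyond the scatter). Among the compounds shown here, this is the first comparison here that isolates a single position, and it shows that the hydrogen on this oxygen can be replaced without losing the effect, since the number moves towards the stronger side, though compound 3 still stands at 71%. No measurement available here accounts for the size or the direction of this step.

On these data alone, it remains open whether a longer chain on this oxygen, such as an ethoxy group, or an amine in place of the hydroxy group, would move the number further. As far as these compounds go, it is also open whether the same change gives a similar step when the rest of the molecule differs.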